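Shortening the chain on compound 2: an alkene in place

The compounds below may be only part of what the source reports. "The series", "measured", "known", "first", "only" and "open" are said of these compounds alone.

In a functional assay on MCF7 cells (Homo sapiens) for antiproliferative activity (on this read-out lower numbers stand for stronger inhibition and higher numbers for weaker inhibition), three compounds have been measured:
compound 1 `C#CCCCn1c(Cc2cc(OC)c(OC)c(OC)c2)nc2c(N)nc(F)nc21` gives 11000 nM;
compound 2 `C#CCCCn1c(Cc2cc(OC)c(OC)c(OC)c2)nc2c(N)ncnc21` gives 24000 nM;
compound 3 `CC#CCCn1c(Cc2cc(OC)c(OC)c(OC)c2)nc2c(N)nc(F)nc21` gives 37200 nM.

Compound 2 holds the second highest of the three numbers. Its nearest neighbour is compound 3, whose number lies within the scatter of it, so the two cannot be ranked. Compound 1 sits clearly lower: a 2.2-fold higher number from compound 1 to compound 2 (0.34 log units; beyond the scatter).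

Compound 4 `C/C=C/Cn1c(Cc2cc(OC)c(OC)c(OC)c2)nc2c(N)ncnc21` is not yet measured. It differs from compound 2 in one place: prop-1-en-1-yl in place of but-3-yn-1-yl on a saturated chain carbon bound to an aromatic nitrogen. Among the measured compounds shown here, of the measured steps, only the one along the same chain bears on this change, and that step was modest: a 3.4-fold higher number from compound 1 to compound 3 (0.53 log units; beyond the scatter). The step that removed fluoro from compound 1 to compound 2 concerns another part of the core and says nothing about the chain. For the measured compounds named here, no measured pair shows an alkene entering for an alkyne, so the direction rests on one chain step alone.

Given that the only chain change weakened inhibition modestly, compound 4 is expected to give 35000 nM in this assay, within 12000 nM to 100000 nM. That expectation means a step of a 1.5-fold higher number from compound 2 to compound 4 (0.16 log units; within the scatter), possibly no larger than the scatter.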

Compound 4, half-maximal inhibitory concentration: 51300 nM
For compound 4 the middle estimate is 1.5-fold (0.17 log units) below the measured one, within the range that was stated.
By their numbers in this assay, from the lowest: compound 1; then compounds 2, 3 and 4 (each within the scatter of the next, the first and the last beyond it).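

In this assay, the step of a 2.1-fold higher number from compound 2 to compound 4 (0.33 log units; beyond the scatter) is the first one shown in which a double bond stands in this chain instead of a triple bond, and the group that enters, prop-1-en-1-yl, has 3 heavy atoms against the 4 of but-3-yn-1-yl. The only earlier chain step, a 3.4-fold higher number from compound 1 to compound 3 (0.53 log units; beyond the scatter), kept the triple bond and was read on the core that carries fluoro, so the new step extends the picture to a different kind of chain and to the core without fluoro, and among the compounds shown both changes on the saturated chain carbon bound to an aromatic nitrogen raise the number, with none going against this. Nothing available to this account explains the size or direction of the step.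

The step from compound 2 to compound 4 changes chain length and bond type together, so the share of each stays unresolved, and a saturated butyl chain or but-3-en-1-yl would be needed to separate them. Also open, on these data alone, is whether a longer chain, or a chain ending in an amine, would lower the number at this place.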